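A few compounds are considered here, and "the series" means these few. Any claim that something is new, unique, unknown or untested is made for them only; others in the source may bear on it.

The measured compounds and their growth-inhibition values:

Compound 1, `COc1ccc(/C=N\NC(=S)NC(C)(C)CCC[C@](C)(O)[C@@H]2CC=C(C)CC2)cc1`, gives 57000 nM.
Compound 2, `CC1=CC[C@@H]([C@@](C)(O)CCCC(C)(C)NC(=S)N/N=C\c2ccc(O)cc2)CC1`, gives 6070 nM.
Compound 3, `CC1=CC[C@@H]([C@@](C)(O)CCCC(C)(C)NC(=S)N/N=C\c2ccc(Cl)cc2)CC1`, gives 36400 nM.

These three numbers come from a functional assay on NCI/ADR cells (Homo sapiens) for cytotoxicity, read by sulforhodamine B assay; a higher number here means a weaker inhibitor of growth, a lower number a stronger inhibitor of growth. Compound 3 stands second highest of the three: its nearest neighbour is compound 1, and the gap between them, a 1.6-fold lower number from compound 1 to compound 3 (0.19 log units; within the scatter), lies within the scatter. Compound 2 is furthest away, the step of a 6.0-fold higher number from compound 2 to compound 3 (0.78 log units; beyond the scatter) being a modest one beyond the scatter, so compound 2 is the only one of the three that clearly separates from the others.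

Compound 4, `CC1=CC[C@@H]([C@@](C)(O)CCCC(C)(C)NC(=S)N/N=C(/C)c2ccccc2)CC1`, has not been measured. Its difference from compound 3 is a group of 9 heavy atoms (8 carbon, 1 nitrogen; one six-membered aromatic ring of carbon only) in place of a group of 9 heavy atoms (7 carbon, 1 nitrogen, 1 chlorine; one six-membered aromatic ring of carbon only), on an amide-type nitrogen. In plain terms, the chlorine-bearing group gives way to one with an extra carbon and no chlorine, all else unchanged.

Going by the values given here, no measured step makes exactly this change. The nearest guides are a 1.6-fold lower number from compound 1 to compound 3 (0.19 log units; within the scatter) and a 6.0-fold higher number from compound 2 to compound 3 (0.78 log units; beyond the scatter), which show that exchanging chloro for methoxy at this part of the molecule moves the number little, while hydroxy in place of either gives a modest improvement. Compound 4 carries no hydroxy, so the step of a 1.1-fold higher number from compound 3 to compound 4 (0.04 log units; within the scatter) is expected to fall within the scatter. For compound 4 the estimate in this assay is 40000 nM, with a range from 12000 nM to 130000 nM.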

Compound 4, concentration for total growth inhibition: > 100000 nM
Compound 4: a limit, no number; the forecaster's own chance of this, stated with the estimate: 10%; middle value at least 2.5-fold (0.39 log units) away from the limit.
By their numbers in this assay, from the lowest: compound 2; then compounds 3 and 1 (each within the scatter of the next). At a limit, above all of these: compound 4.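

Compound 4 gives no number in this assay, only a limit: the limit of > 100000 nM in this assay, at which 1 of the 4 values shown sits.

The earlier compounds shown here varied only a single substituent on the aromatic ring, whereas this result tests a change in the whole group on the amide-type nitrogen, and that change does shift the read-out: the step is an at least 2.7-fold higher number from compound 3 to compound 4 (0.43 log units; beyond the scatter), so the new group gives weaker growth inhibition than the chlorine-bearing group of compound 3. The gap to the hydroxy-bearing group is wider still, at an at least 16-fold higher number from compound 2 to compound 4 (1.21 log units; beyond the scatter), which leaves compound 2 clearly the stronger inhibitor of the two. Against the methoxy-bearing group the step is an at least 1.7-fold higher number from compound 1 to compound 4 (0.24 log units; that floor lies within the scatter), and since that floor lies within the scatter, the limit alone does not separate these two compounds.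

The step swaps the chlorine for an extra carbon elsewhere in the group, so these compounds cannot show which of the two alterations accounts for the loss. As far as these compounds go, whether an amine or a carboxylic acid on the aromatic ring would match the hydroxy of compound 2 also remains open.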